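The source may report more compounds than this note shows. Statements on the series, on what has been measured and on what is new or still open speak of the compounds shown alone.

Compound 1 `COc1ccc(/C=C/C(=O)c2ccc(OC)c3c2OC(C)(C)C=C3)cc1O` carries a free hydroxyl on its outer aromatic ring, and in a functional assay on HepG2 cells (Homo sapiens) for cytotoxicity, read by MTT assay (a lower number here means a stronger inhibitor, a higher number a weaker inhibitor), compound 1 gives 450 nM. Compound 3 `COc1ccc(/C=C/C(=O)Oc2cc(/C=C/C(=O)c3ccc(OC)c4c3OC(C)(C)C=C4)ccc2OC)cc1` carries a (2-(4-methoxyphenyl)ethenyl)carbonyl on that oxygen, and in this assay compound 3 gives 430 nM, the step being a 1.0-fold lower number from compound 1 to compound 3 (0.02 log units; within the scatter). Compound 2 `C=CCOc1cc(/C=C/C(=O)c2ccc(OC)c3c2OC(C)(C)C=C3)ccc1OC` carries an allyl on the same oxygen. In this assay compound 2 reaches only a limit, > 10000 nM, which is the limit of > 10000 nM in this assay, at which 1 of the 3 values shown sits. That places compound 2 at the weak end of the three, since an at least 22-fold higher number from compound 1 to compound 2 (1.34 log units; beyond the scatter) and an at least 23-fold lower number from compound 2 to compound 3 (1.36 log units; beyond the scatter).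

Compound 4 `COc1ccc(/C=C/C(=O)c2ccc(OC)c3c2OC(C)(C)C=C3)cc1OS(=O)(=O)c1ccc(C)cc1` differs from compound 2 in one place: (4-methylphenyl)sulfonyl in place of allyl on an oxygen on an aromatic ring. Among the compounds with values here, two measured steps bear on this change. Allyl on that oxygen gave an at least 22-fold higher number from compound 1 to compound 2 (1.34 log units; beyond the scatter), whereas a larger carbonyl-linked substituent on the same oxygen gave an at least 23-fold lower number from compound 2 to compound 3 (1.36 log units; beyond the scatter). On these data alone, the (4-methylphenyl)sulfonyl, like the (2-(4-methoxyphenyl)ethenyl)carbonyl, is a ring-bearing group, so a drop from compound 2 toward the level of compound 3 is expected, though only compound 3 supports that expectation and the sulfonyl link is untested. Compound 4 is therefore expected to give 1500 nM, between 300 nM and 10000 nM. The expected step is an at least 6.6-fold lower number from compound 2 to compound 4 (0.82 log units; beyond the scatter).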

Compound 4, half-maximal inhibitory concentration: 3600 nM
Compound 4: the middle estimate sits 2.4-fold (0.38 log units) below what was measured; measured number inside the range.
By their numbers in this assay, from the lowest: compounds 3 and 1 (each within the scatter of the next); then compound 4. At a limit, above all of these: compound 2.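

In this assay a ring-bearing group on this oxygen does not by itself carry the level of compound 3, since the (4-methylphenyl)sulfonyl gives an 8.4-fold higher number from compound 3 to compound 4 (0.92 log units; beyond the scatter) and, measured against the free hydroxyl, an 8.0-fold higher number from compound 1 to compound 4 (0.90 log units; beyond the scatter). Until now the hydroxyl and the carbonyl-linked group stood within the scatter of each other, so compound 4 is the first of the shown compounds to separate a ring-bearing substituent on this oxygen from the free hydroxyl, while it still stays clear of the allyl ether with an at least 2.7-fold lower number from compound 2 to compound 4 (0.44 log units; beyond the scatter). That last step gives only a lower bound on the gap, and the limit in it is that of compound 2: the limit of > 10000 nM in this assay, at which 1 of the 4 values shown sits.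

The compounds shown leave open whether the sulfonyl link, the methyl on the outer ring or the missing ethenyl chain sets compound 4 apart from compound 3. A plain benzoyl or a methanesulfonyl on the same oxygen would pull these apart, and a small acetyl would show whether any ring is needed at all on a carbonyl-linked group.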